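A Fourth Aryl Variant on a Shared Core

A few compounds are considered here, and "the series" means these few. Any claim that something is new, unique, unknown or untested is made for them only; others in the source may bear on it.

The three measured compounds are:
Compound 1 `C=CC(=O)Nc1cccc(NC(=O)CSc2nc(Nc3ccccc3Cl)c3ccccc3n2)c1` gives 12700 nM in a functional assay on MDA-MB-231 cells (Homo sapiens) for inhibition, read by MTT assay, with a stated time of 72 h; a higher number here means a weaker inhibitor, a lower number a stronger inhibitor.
Compound 2 `C=CC(=O)Nc1cccc(NC(=O)CSc2nc(Nc3cccc(F)c3)c3ccccc3n2)c1` gives 8160 nM in this assay.
Compound 3 `C=CC(=O)Nc1cccc(NC(=O)CSc2nc(Nc3cccc(OC)c3)c3ccccc3n2)c1` gives 12900 nM in this assay.

All three share the same core and differ only in the aryl group carried on a nitrogen attached to an aromatic ring. The spread among them is small: a 1.6-fold lower number from compound 1 to compound 2 (0.19 log units; within the scatter), a 1.0-fold higher number from compound 1 to compound 3 (0.01 log units; within the scatter) and a 1.6-fold higher number from compound 2 to compound 3 (0.20 log units; within the scatter). Compound 3 therefore sits within the scatter of both compound 1 and compound 2, so none of the three can be called stronger or weaker than another on these numbers.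

Compound 4 `C=CC(=O)Nc1cccc(NC(=O)CSc2nc(Nc3ccc(Cl)cc3)c3ccccc3n2)c1` continues the same kind of swap: 4-chlorophenyl in place of 3-methoxyphenyl on a nitrogen on an aromatic ring. Within the data shown here, no measured pair covers a chlorine in this ring position, but the three steps above all stayed within the scatter when the aryl group was changed, so a similar outcome is the most the data support. The expectation for compound 4 in this assay is a value close to that of compound 3, with a 1.2-fold lower number from compound 3 to compound 4 (0.09 log units; within the scatter) as the expected step. Compound 4 is thus estimated at 10500 nM, with a range from 4500 nM to 25000 nM.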

Compound 4, half-maximal inhibitory concentration: 10300 nM
Compound 4: middle estimate off by 1.0-fold (0.01 log units), on the high side; the range from low to high includes it.
By their numbers in this assay, from the lowest: compounds 2, 4, 1 and 3 (each within the scatter of the next).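

In this assay the aryl group on the nitrogen now comes in four forms, and compound 4 adds a pair that carries the same chlorine at two ring positions: 4-chlorophenyl in place of 2-chlorophenyl gives a 1.2-fold lower number from compound 1 to compound 4 (0.09 log units; within the scatter) as the whole change. Replacing a different substituent gives steps of similar size, with a 1.3-fold lower number from compound 3 to compound 4 (0.10 log units; within the scatter) and a 1.3-fold higher number from compound 2 to compound 4 (0.10 log units; within the scatter) in the same comparison. At this position, then, neither the substituent among chloro, fluoro and methoxy nor the ring positions shown separates the four compounds on these numbers, and no supporting evidence bears on why the swaps come out so evenly.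

Every group shown is a phenyl ring with one substituent, so an unsubstituted phenyl, an amine, a carboxylic acid or a longer chain at this place remains open. All the steps here lie within the scatter, so these compounds cannot tell whether any change on this nitrogen would shift the number beyond it.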